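Fluoromethyl on the ring carbon: lipophilicity notes

The source may hold more compounds than are shown below. What is called first, only, known or untested is meant among the compounds shown, and "the series" means these compounds.

Measured in a physicochemical assay for lipophilicity, at pH 7.4; a higher number here means a more lipophilic compound, a lower number a more polar compound:
compound 1 `CNC(=O)c1cc(C(=O)NCCC[C@H]2OC[C@H](N)CO2)cc2c1OC[C@H]2c1ccccc1` gives 2.6
compound 2 `CNC(=O)c1cc(C(=O)NCCC[C@H]2OC[C@H](N)CO2)cc2c1O[C@H](CF)[C@H]2c1ccccc1` gives 2.9
compound 3 `CNC(=O)c1cc(C(=O)NC)c2c(c1)[C@H](c1ccccc1)CO2` gives 3.2

Compound 2 differs from compound 1 by fluoromethyl in place of hydrogen on a saturated ring carbon. This change gave a number 0.30 log units higher from compound 1 to compound 2 (within the scatter).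

Compound 3 differs from compound 1 in the core by a hydrogen atom in place of a group of 9 heavy atoms (6 carbon, 1 nitrogen, 2 oxygen; one six-membered non-aromatic ring with 2 hetero atoms), on a saturated chain carbon bound to an amide-type nitrogen. That difference gave a number 0.60 log units higher from compound 1 to compound 3 (beyond the scatter). Compound 3 and compound 2 lie within the scatter of each other.

Compound 4 `CNC(=O)c1cc(C(=O)NC)c2c(c1)[C@H](c1ccccc1)[C@@H](CF)O2` has not been measured. It differs from compound 3 by fluoromethyl in place of hydrogen on a saturated ring carbon. The change is the same one that leads from compound 1 to compound 2; it occurs twice among these compounds.

Going by the values given here, the step from compound 3 to compound 4 is expected to be a number 0.30 log units higher from compound 3 to compound 4 (within the scatter), because the one measured example of this change gave a number 0.30 log units higher from compound 1 to compound 2 (within the scatter). Compound 4 is therefore estimated at 3.5. The estimate for compound 4 spans 3.2 to 3.8, the width reflecting that a single measured pair carries the expectation.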

Compound 4, distribution coefficient: 3.3
Beside the measured number, compound 4's estimate is 0.20 log units above it; the measured number falls inside the stated range.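

In this assay, fluoromethyl in place of hydrogen on a saturated ring carbon gave a number 0.10 log units higher from compound 3 to compound 4 (within the scatter) on this core and a number 0.30 log units higher from compound 1 to compound 2 (within the scatter) on the core of compound 1, and both steps lie within the scatter, so the change carries across these two cores only in the sense that neither step is resolved from repeat measurement. The larger difference in the pair, a number 0.40 log units higher from compound 2 to compound 4 (beyond the scatter) with the fluoromethyl group present, stands beyond the scatter, as does a number 0.60 log units higher from compound 1 to compound 3 (beyond the scatter) without it. Two pairs do not show that fluoromethyl leaves this assay unmoved on every core, nor do they give a reliable size for the step.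

Still open, as far as these compounds go, is whether trifluoromethyl or a longer chain on the same saturated ring carbon, or a carboxylic acid in place of the group of 9 heavy atoms, would give a step beyond the scatter. Nothing measured here bears on why the steps have these sizes.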